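This account rests on a few compounds, and the source may have more. Where it says the series, first, only, none or still open, it means among the compounds named here.

Compound 1 `COc1ccc(-c2cc(C(=O)/C=C/c3cc(OC)c(OC)c(OC)c3)ccc2N)cc1OC`, compound 2 `COc1ccc(-c2cc(C(=O)/C=C/c3cccc(OC)c3OC)ccc2N)cc1OC` and compound 3 `COc1cc(/C=C/C(=O)c2ccc(N)c(-c3ccc(F)cc3)c2)cc(OC)c1OC` share a core and were each tested in a functional assay on SW480 cells (Homo sapiens) for cytotoxicity, read by sulforhodamine B assay, with a stated time of 48 h; on this read-out higher numbers stand for weaker inhibition and lower numbers for stronger inhibition. In this assay compound 1 gives 5630 nM, compound 2 gives 8330 nM and compound 3 gives 6120 nM, and all three numbers fall within the usual scatter of one another. The difference between the core of compound 1 and the core of compound 2 is not broken down here. Compound 3 differs from compound 1 in one place, (4-fluorophenyl in place of 3,4-dimethoxyphenyl on an aromatic carbon), and this step is a 1.1-fold higher number from compound 1 to compound 3 (0.04 log units; within the scatter), so the exchange left the read-out essentially unchanged in that pair. Compound 4 `COc1cccc(/C=C/C(=O)c2ccc(N)c(-c3ccc(F)cc3)c2)c1OC` has not yet been measured in this assay. It differs from compound 2 by the same change, (4-fluorophenyl in place of 3,4-dimethoxyphenyl on an aromatic carbon), made at a place described in the same words. Resting on the step of a 1.1-fold higher number from compound 1 to compound 3 (0.04 log units; within the scatter), which stayed within the scatter, the expected step is a 1.1-fold higher number from compound 2 to compound 4 (0.03 log units; within the scatter). Compound 4 is thus estimated to give 9000 nM in this assay, with a likely range from 4500 nM to 18000 nM.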

Compound 4, half-maximal inhibitory concentration: 12500 nM
Beside the measured number, compound 4's estimate is 1.4-fold (0.14 log units) below it; low and high end bracket the measured number.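

Carried to a second core, the exchange of 3,4-dimethoxyphenyl for 4-fluorophenyl gives a 1.5-fold higher number from compound 2 to compound 4 (0.18 log units; within the scatter) in this assay, so here too the step is no larger than the differences seen between repeated measurements. Set side by side, the two steps do not differ in any way that can be told apart: the same change on two cores in this assay, a 1.1-fold higher number (0.04 log units; within the scatter) from compound 1 to compound 3 and a 1.5-fold higher number (0.18 log units; within the scatter) from compound 2 to compound 4, 1.4-fold (0.14 log units) apart, within the scatter of two such steps. This shows that in these two pairs the exchange changed the read-out very little on either core, but two pairs that both lie within the scatter cannot prove that the change always carries over, nor rule out a small real difference between the cores.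

The compounds shown leave open what happens when something quite different stands at this place, such as a carboxylic acid or a longer alkyl chain in place of the two phenyl groups. They also leave open whether the amino group matters, which replacing it with a hydroxyl group could test.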